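The compounds below may be only part of what the source reports. "The series", "measured", "known", "first", "only" and "open" are said of these compounds alone.

Measured so far: compound 1 `CCCCCCCCCCC[C@@H](C[C@@H]1OC(=O)[C@H]1CCCCCC)OC(=O)[C@@H](N)CC(C)C`, compound 2 `CCCCCCCCCCC[C@@H](C[C@@H]1OC(=O)[C@H]1CCCCCC)OC(=O)CNC(=O)OCc1ccccc1`, compound 3 `CCCCCCCCCCC[C@@H](C[C@@H]1OC(=O)[C@H]1CCCCCC)OC(=O)[C@H](C)NC=O`.

In an assay on COS-7 cells for inhibition of diacylglycerol lipase-alpha (Homo sapiens), read by scintillation counting (a lower number here means a stronger inhibitor, a higher number a weaker inhibitor), compound 1 gives only a limit, > 25000 nM. Compound 2 likewise gives only a limit, > 25000 nM. For the measured compounds named here, compound 3 gives 43 nM and is the only compound with a number in this assay; the other two values sit at the limit of > 25000 nM in this assay, at which 2 of the 3 values shown sit. Compound 4 `CCCCCCCCCCC[C@@H](C[C@@H]1OC(=O)[C@H]1CCCCCC)OC(=O)[C@@H](NC(C)=O)C(C)C` differs from compound 3 in one place: a group of 8 heavy atoms (6 carbon, 1 nitrogen, 1 oxygen; no ring) in place of a group of 5 heavy atoms (3 carbon, 1 nitrogen, 1 oxygen; no ring), on a carbonyl carbon. The measured steps onto this carbonyl carbon, an at least 580-fold lower number from compound 1 to compound 3 (2.76 log units; beyond the scatter) and an at least 580-fold lower number from compound 2 to compound 3 (2.76 log units; beyond the scatter), were both large, so the group here decides the outcome, though both earlier steps start from a limit. Compound 4 keeps the acylamino form of compound 3 with the larger 1-acetamido-2-methylpropyl group; a moderate weakening is expected, a 3.5-fold higher number from compound 3 to compound 4 (0.54 log units; beyond the scatter). Compound 4 is estimated at 150 nM, within 30 nM to 3000 nM.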

Compound 4, half-maximal inhibitory concentration: 460 nM
Estimate against measurement, compound 4: 3.1-fold (0.49 log units) below; measured number inside the range.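

In this assay, the acylamino form is not enough on its own to fix the result on this carbonyl carbon, since the group's size or branching still counts: an 11-fold higher number from compound 3 to compound 4 (1.03 log units; beyond the scatter). Even so, compound 4 stays well clear of the two compounds without a number, with an at least 54-fold lower number from compound 2 to compound 4 (1.73 log units; beyond the scatter) and an at least 54-fold lower number from compound 1 to compound 4 (1.73 log units; beyond the scatter). Both of these steps start from a limit, so their true size is unknown: the limit of > 25000 nM in this assay, at which 2 of the 4 values shown sit.

From the compounds shown here alone, the step from compound 3 to compound 4 changes both the acyl part and the side chain, and the share of each remains open. Also open, going by these compounds, is how a urea or a sulfonamide would read in place of the amide.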